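The source may report more compounds than this note shows. Statements on the series, on what has been measured and on what is new or still open speak of the compounds shown alone.

Measured in an ADME assay on microsomes from liver (Rattus norvegicus) for metabolic stability, read by LC-MS, with a stated time of 15 min, tested at 1 uM; on this read-out higher numbers stand for a more stable compound and lower numbers for a less stable compound:
- compound 1 `O=C(CCS(=O)(=O)c1cccc2ncsc12)N1CCN(c2ccc(C(F)(F)F)cn2)CC1`: 41%
- compound 2 `Cc1cc(F)cnc1N1CCN(C(=O)CCCc2cccc3ncccc23)[C@@H](C)C1`: 0.2%
- compound 3 `Cc1cc(F)cnc1N1CCN(C(=O)CCS(=O)(=O)c2cccc3ncsc23)[C@@H](C)C1`: 9.6%

Compound 2 at 0.2% lies within the usual scatter of compound 3 at 9.6%, while compound 1 at 41% stands higher than compound 2, beyond the scatter.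

The next compound is compound 4 `Cc1cc(F)cnc1N1CCN(C(=O)CCCc2cccc3nc(N)sc23)[C@@H](C)C1`, with 2-amino-1,3-benzothiazol-7-yl in place of quinolin-5-yl on a saturated chain carbon, three bonds along the chain from a carbonyl carbon.

For the measured compounds named here, no measured pair shows this change alone, so the expectation is loose. Because compound 2 gives 0.2% there is almost no room to fall, so a small rise within the scatter is expected. The expected move is a number 3.8 percentage points higher from compound 2 to compound 4 (within the scatter). For compound 4 the estimated value is 4%, with an expected range of 0.5% to 15%.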

Compound 4, percent of the compound remaining: 3.7%
Estimate against measurement, compound 4: 0.3 percentage points above, and the stated range covers the measured number.
By their numbers in this assay, from the lowest: compounds 2, 4 and 3 (each within the scatter of the next); then compound 1.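

In this assay, for the compounds shown here, 2-amino-1,3-benzothiazol-7-yl in place of quinolin-5-yl on a saturated chain carbon gives a number 3.5 percentage points higher from compound 2 to compound 4 (within the scatter), the first direct reading of a change at this position. Two groups with different rings and different hydrogen-bond donor and acceptor counts thus cannot be told apart here, with both compounds close to the bottom of the scale. No measurement shown explains this result. As far as these compounds go, what a plain phenyl ring or a carboxylic acid at this place would give stays open, as does the effect of a longer chain.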